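This account rests on a few compounds, and the source may have more. Where it says the series, first, only, none or still open, it means among the compounds named here.

Compound 1 `COc1cc(-c2nnc3n2NC(c2ccco2)C(C(=O)c2ccccc2C)S3)cc(OC)c1OC` is the starting point. In a functional assay on HepG2 cells (Homo sapiens) for cytotoxicity, read by MTT assay, with a stated time of 48 h (a lower number here means a stronger inhibitor, a higher number a weaker inhibitor), compound 1 gives 63000 nM. Compound 3 `COc1cc(-c2nnc3n2NC(c2ccco2)C(C(=O)c2ccccc2)S3)cc(OC)c1OC` differs only in the group on the carbonyl carbon and gives 90900 nM; the step of a 1.4-fold higher number from compound 1 to compound 3 (0.16 log units; within the scatter) lies within the scatter. For compound 2 `COc1cc(-c2nnc3n2NC(c2ccco2)C(C(=O)c2ccc(F)cc2)S3)cc(OC)c1OC` this assay reports only a limit, > 100000 nM, which is the assay's floor (the limit of > 100000 nM in this assay, at which 1 of the 3 values shown sits). The step of an at least 1.5-fold higher number from compound 1 to compound 2 (0.20 log units; that floor lies within the scatter) is likewise small. Compound 4 `COc1cc(-c2nnc3n2NC(c2ccco2)C(C(=O)c2cccc4ccccc24)S3)cc(OC)c1OC` has not yet been measured; it differs from compound 1 by naphthalen-1-yl in place of 2-methylphenyl on a carbonyl carbon. Both measured changes on this carbonyl carbon moved the number little, so no step beyond the scatter is expected for compound 4, and its value in this assay is estimated at 70000 nM (range 30000 nM to 150000 nM), a step of a 1.1-fold higher number from compound 1 to compound 4 (0.05 log units; within the scatter).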

Compound 4, half-maximal inhibitory concentration: 33900 nM
The estimate for compound 4 lay 2.1-fold (0.31 log units) above the measured number, and the stated range covers the measured number.
By their numbers in this assay, from the lowest: compounds 4, 1 and 3 (each within the scatter of the next, the first and the last beyond it). At a limit, above all of these: compound 2.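

Naphthalen-1-yl on the carbonyl carbon gives the first steps at this position that lie beyond the scatter, both modest: one against phenyl (a 2.7-fold lower number from compound 3 to compound 4 (0.43 log units; beyond the scatter)) and one against 4-fluorophenyl (an at least 2.9-fold lower number from compound 2 to compound 4 (0.46 log units; beyond the scatter)). Against 2-methylphenyl, the same change stays within the scatter (a 1.9-fold lower number from compound 1 to compound 4 (0.27 log units; within the scatter)). The step from compound 2 starts from a limit, not a number: (the limit of > 100000 nM in this assay, at which 1 of the 4 values shown sits).

Still open, on these data alone, is whether naphthalen-2-yl would behave like naphthalen-1-yl at this position. Also open, as far as these compounds go, is how a non-aromatic group such as cyclohexyl, or a phenyl ring carrying an amine or a carboxylic acid, would read here.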